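A few compounds are considered here, and "the series" means these few. Any claim that something is new, unique, unknown or untested is made for them only; others in the source may bear on it.

Compound 1 `Fc1ccccc1-c1ccc2[nH]c(C3=NOC4(CCCCC4)C3)nc2c1` gives in an ADME assay on microsomes from liver (Canis lupus familiaris) for metabolic stability, with a stated time of 10 min (a higher number here means that more of the compound is left, a lower number that less of the compound is left), the value 47%
Compound 2 `FC(F)Oc1ccccc1-c1ccc2[nH]c(C3=NOC4(CCCCC4)C3)nc2c1` gives in this assay the value 81%

Compound 2 holds the higher of the two numbers in this assay and is the starting point for the next change. For the measured compounds named here, the one measured step is a number 34 percentage points higher from compound 1 to compound 2 (beyond the scatter) and it is large and beyond the scatter, with difluoromethoxy in place of fluoro on an aromatic carbon.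

Compound 3 `CC(C)(O)c1ccccc1-c1ccc2[nH]c(C3=NOC4(CCCCC4)C3)nc2c1` differs at the group that changed in that step. Its difference from compound 2 is 1-hydroxy-1-methylethyl in place of difluoromethoxy on an aromatic carbon so that 1-hydroxy-1-methylethyl stands in place of difluoromethoxy on an aromatic carbon, ortho to a large group. Going by the values given here, no measured step covers this exchange, so the one step bears on it only indirectly, by showing that a change of this group can shift the number by a large amount. Compound 2 at 81% sits high, which makes a fall more likely than a rise. The estimated step is a number 16 percentage points lower from compound 2 to compound 3 (beyond the scatter) and is expected to be a moderate fall with wide uncertainty. For compound 3 the estimate is 65% with an expected range from 40% to 90% in this read-out.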

Compound 3, percent of the compound remaining: 4.4%
Beside the measured number, compound 3's estimate is 60.6 percentage points above it; the measured number lies below the stated range.
By their numbers in this assay, from the lowest: compound 3; then compound 1; then compound 2.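

The new compound shows that this position, on an aromatic carbon ortho to a large group, can move the number in this assay down as well as up, and by a large amount in both directions (a number 76.6 percentage points lower from compound 2 to compound 3 (beyond the scatter)). The 1-hydroxy-1-methylethyl group also falls short of fluoro on the same core (a number 42.6 percentage points lower from compound 1 to compound 3 (beyond the scatter)), so the three groups now stand in a clear order, with difluoromethoxy at the top and 1-hydroxy-1-methylethyl at the bottom. Difluoromethoxy and 1-hydroxy-1-methylethyl have the same count of 4 heavy atoms, so that count does not separate them, and nothing measured here accounts for the fall.

On these data alone, it remains open whether the low number goes with the hydroxyl of the entering group or with its branched carbon frame, a question on which a tert-butyl group or a methoxy group at this place would bear. As far as these compounds go, it is also open how an amine or a carboxylic acid would fare here, and whether these differences would hold on a different core.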